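A few compounds are considered here, and "the series" means these few. Any claim that something is new, unique, unknown or untested is made for them only; others in the source may bear on it.

Measured in a physicochemical assay for solubility, read by spectrophotometry, measured as kinetic solubility, at pH 8, tested at 500 uM; a lower number here means a less soluble compound, a higher number a more soluble compound:
- Compound 1 `CN1CCC(CNS(=O)(=O)c2ccccc2Nc2cc(-c3ccc4ccn(C)c4c3)c3nccnc3c2)C1`: 35 ug/mL
- Compound 2 `Cn1cc(NC(=O)c2ccncc2Nc2cc(-c3ccc4ccn(C)c4c3)c3nccnc3c2)cn1`: 2 ug/mL
- Compound 3 `CN1CCC(NC(=O)c2ccncc2Nc2cc(-c3ccc4ccn(C)c4c3)c3nccnc3c2)CC1`: 246 ug/mL

Of these three, compound 3 has the highest number, at 246 ug/mL. Compound 4 `Cn1ccc2ccc(-c3cc(Nc4cnccc4C(=O)NCC4COCCN4)cc4nccnc34)cc21` differs from it in one place: (morpholin-3-yl)methyl in place of 1-methylpiperidin-4-yl on an amide-type nitrogen. Going by the values given here, only one measured step touches that place, a 120-fold higher number from compound 2 to compound 3 (2.09 log units; beyond the scatter). That step was large, but it brought in the 1-methylpiperidin-4-yl group, whereas compound 3 and compound 4 both carry a six-membered non-aromatic ring there. Compound 1 differs from compound 3 in more than this one group, so it offers no clean comparison. No step beyond the scatter is therefore expected in this assay, and the estimate is a 1.4-fold lower number from compound 3 to compound 4 (0.16 log units; within the scatter). Compound 4 is expected at about 170 ug/mL, with an estimated range of 70 ug/mL to 280 ug/mL.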

Compound 4, solubility: 239 ug/mL
Beside the measured number, compound 4's estimate is 1.4-fold (0.15 log units) below it; low and high end bracket the measured number.
By their numbers in this assay, from the lowest: compound 2; then compound 1; then compounds 4 and 3 (each within the scatter of the next).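

In this assay, the step of a 1.0-fold lower number from compound 3 to compound 4 (0.01 log units; within the scatter) shows that this amide-type nitrogen can carry a (morpholin-3-yl)methyl group in place of a 1-methylpiperidin-4-yl group with no change beyond the scatter. The step of a 120-fold higher number from compound 2 to compound 4 (2.08 log units; beyond the scatter) shows that the large difference from the 1-methyl-1H-pyrazol-4-yl compound is not tied to the 1-methylpiperidin-4-yl group alone. As far as these compounds go, whether an open-chain amine or a carboxylic acid on this nitrogen would read the same remains open. Nothing available explains why these two groups read alike.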